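This account rests on a few compounds, and the source may have more. Where it says the series, first, only, none or still open, it means among the compounds named here.

Measured in a functional assay on MCF7 cells (Homo sapiens) for inhibition, read by MTT assay, with a stated time of 72 h, tested at 50 uM; a higher number here means more inhibition of growth at the concentration tested, a lower number less inhibition of growth:
- compound 1 `C=CCc1ccc(OCc2cn(-c3cc(OC)c(OC)c(OC)c3)nn2)c(O)c1`: 38.1%
- compound 2 `C=CCc1ccc(OCc2cn(-c3ccccc3Cl)nn2)c(O)c1`: 34.3%
- compound 3 `C=CCc1cc(O)c(O)c(CN2CCC(Cc3ccccc3)CC2)c1`: 86.3%

In this assay, compound 2 gives 34.3%. This lies within the usual scatter of compound 1 at 38.1%, while compound 3 at 86.3% stands higher than compound 2 by well beyond the scatter.

Compound 4 `C=CCc1ccc(OCc2cn(-c3ccc(Br)cc3)nn2)c(O)c1` has 4-bromophenyl in place of 2-chlorophenyl on an aromatic nitrogen. Among the measured compounds shown here, no two measured compounds differ in one place only, so the data offer no direct measure of what such a change does. The expectation therefore stays cautious and rests on the closeness of the two values, compound 2 at 34.3% and compound 1 at 38.1%. The expected step of a number 2.7 percentage points higher from compound 2 to compound 4 (within the scatter) is small, within the scatter, with no firm direction. Compound 4 is estimated at 37%, with an expected range of 20% to 55%.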

Compound 4, percent growth inhibition at one concentration: 29.1%
Compound 4: the middle estimate sits 7.9 percentage points above what was measured; measured number inside the range.
By their numbers in this assay, from the lowest: compounds 4, 2 and 1 (each within the scatter of the next); then compound 3.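

Among the compounds shown here, for 4-bromophenyl in place of 2-chlorophenyl on an aromatic nitrogen, the step of a number 5.2 percentage points lower from compound 2 to compound 4 (within the scatter) is the first comparison in this assay between compounds that differ in one place only. For the compounds shown here, at the concentration tested, this exchange leaves compound 2 and compound 4 within the scatter of each other, although the halogen and its place on the phenyl ring both differ, and the single step cannot separate these two differences. No measured property of either group bears on this result.

The compounds shown leave open whether the halogen or its place on the phenyl ring would matter alone, as a pairing of 2-bromophenyl with 2-chlorophenyl would show. They also leave open how this position would respond to a group of another kind, such as an aminophenyl, a carboxyphenyl or a longer alkyl chain.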